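The source may hold more compounds than are shown below. What is called first, only, known or untested is meant among the compounds shown, and "the series" means these compounds.

Going by the values given here, in a functional assay on HeLa cells (Homo sapiens) for inhibition, read by MTT assay, with a stated time of 72 h (a lower number here means a stronger inhibitor of growth, a higher number a weaker inhibitor of growth), only two compounds have been tested so far. Compound 1 `O=C1CC(N2C(=O)CSC2=S)C(=O)N1c1ccc(Cl)cc1` gives > 100000 nM, which is a limit of the assay and not a number. Among the compounds with values here, compound 2 `O=C1CC(N2C(=O)/C(=C/C(Cl)=C/c3ccc([N+](=O)[O-])cc3)SC2=S)C(=O)N1c1ccc(Cl)cc1` gives 6650 nM, the only true number available in this assay, so it has no measured neighbour to be ranked against.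

Compound 3 `O=C1CC(N2C(=O)/C(=C/C(Cl)=C/c3ccc([N+](=O)[O-])cc3)SC2=S)C(=O)N1c1ccc(O)cc1` differs from compound 2 in one place: hydroxy in place of chloro on an aromatic carbon, para to a large group, which turns the 4-chlorophenyl into a 4-hydroxyphenyl (hydroxy in place of chloro on an aromatic carbon). Within the data shown here, no tested pair shows this exchange, so the data give no direct measure of its size. Among the measured compounds shown here, the only starting point is compound 2 at 6650 nM, and with nothing to suggest a direction, no step beyond the usual scatter is expected in this assay. The estimated step of a 1.2-fold higher number from compound 2 to compound 3 (0.08 log units; within the scatter) is therefore small, though uncertain. Compound 3 is expected at 8000 nM, with an estimated range of 2000 nM to 30000 nM.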

Compound 3, concentration for 50% growth inhibition: 6130 nM
Compound 3: middle estimate off by 1.3-fold (0.12 log units), on the high side; the range from low to high includes it.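

In this assay, going by these compounds alone, the exchange of chloro for hydroxy on an aromatic carbon, para to a large group, gives a 1.1-fold lower number from compound 2 to compound 3 (0.04 log units; within the scatter), and this is the first step at this position that can be read at all. The 4-chlorophenyl and the 4-hydroxyphenyl therefore cannot be told apart in this read-out, even though the entering hydroxy counts one hydrogen-bond donor and one hydrogen-bond acceptor that the leaving chloro does not have. Compound 1 remains a limit of the assay and not a number, so the step between compound 2 and compound 3 is the only measured comparison here: the limit of > 100000 nM in this assay, at which 1 of the 3 values shown sits.

The compounds shown leave open whether this agreement extends beyond these two groups, since an amine, a carboxylic acid, a methoxy group or a longer chain on the same aromatic carbon could give a different reading. One pair also cannot say whether the exchange of chloro for hydroxy would stay within the scatter on a compound with a different substituent on the shared core.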